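Lipophilicity of oxazolidinone amides: from acetoxymethyl to methoxycarbamoyl

The source may hold more compounds than are shown below. What is called first, only, known or untested is meant among the compounds shown, and "the series" means these compounds.

Measured compounds:
compound 1, `CN(CCC#N)C[C@H]1CN(c2ccc(-n3cc(-c4ccccn4)cn3)c(F)c2)C(=O)O1`, 1.9
compound 2, `CC(=O)OC[C@H]1CN(c2ccc(-n3cc(-c4ccccn4)cn3)c(F)c2)C(=O)O1`, 2.09
compound 3, `NC(=O)[C@H]1CN(c2ccc(-n3cc(-c4ccccn4)cn3)c(F)c2)C(=O)O1`, 1.59

Of the compounds shown here, three sharing one core have been measured in a physicochemical assay for lipophilicity, read by HPLC, measured as octanol-water partition; on this read-out lower numbers stand for lower lipophilicity and higher numbers for higher lipophilicity. Compound 2 gives 2.09 and stands highest of the three numbers; compound 1 is nearest, with a number 0.19 log units higher from compound 1 to compound 2 (within the scatter), and compound 3 is furthest, with a number 0.50 log units lower from compound 2 to compound 3 (beyond the scatter). Between compound 1 and compound 3 the step is a number 0.31 log units lower from compound 1 to compound 3 (beyond the scatter).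

Compound 4, `CONC(=O)[C@H]1CN(c2ccc(-n3cc(-c4ccccn4)cn3)c(F)c2)C(=O)O1`, has not yet been measured in this assay. Its difference from compound 2 is methoxycarbamoyl in place of acetoxymethyl on a saturated ring carbon.

Within the data shown here, the step that bears most directly on this change is the one from compound 2 to compound 3, where an amide took the place of the acetoxymethyl group on the same ring carbon and the number fell by a number 0.50 log units lower from compound 2 to compound 3 (beyond the scatter). Compound 4 carries a methoxycarbamoyl group at that position, which shares the amide carbonyl and the hydrogen-bond donor of compound 3 while adding a methoxy group. Among the measured compounds shown here, a step downward from compound 2 is therefore expected, somewhat smaller than the one to compound 3; the expected step is a number 0.37 log units lower from compound 2 to compound 4 (beyond the scatter). Compound 4 is estimated at 1.72, with a range from 1.42 to 2.02.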

Compound 4, partition coefficient: >= 1.58
Compound 4: only a limit was reported (the forecaster's own chance of this, stated with the estimate: 0%); the middle value lies beyond the limit too.
By their numbers in this assay, from the lowest: compound 3; then compounds 1 and 2 (each within the scatter of the next).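

In this assay compound 4 gives >= 1.58, which is a limit and not a number. Its steps from compound 1, compound 2 and compound 3 therefore cannot be read. The compounds shown leave open where compound 4 stands among the three, and how methoxy in place of hydrogen on an amide-type nitrogen shifts the number from compound 3.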